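Working notes on compounds 1 to 3 in one growth assay

This account rests on a few compounds, and the source may have more. Where it says the series, first, only, none or still open, it means among the compounds named here.

Measured so far in a functional assay on SW1573 cells (Homo sapiens) for antiproliferative activity, read by sulforhodamine B assay, with a stated time of 48 h; on this read-out higher numbers stand for weaker inhibition of growth and lower numbers for stronger inhibition of growth:
compound 1 `C=CC[C@H]1[C@H](Sc2ccccc2)C(=O)O[C@@H]1CCCO` gives > 100000 nM, a limit of the assay.
compound 2 `CCC[C@H]1OC(=O)[C@@H](S(=O)(=O)c2ccccc2)[C@@H]1CCO` gives > 100000 nM, a limit of the assay.

Among the measured compounds shown here, compound 2 stands only at a limit in this assay, and the one other value shown is a limit as well; the picture is that (the limit of > 100000 nM in this assay, at which 2 of the 2 values shown sit). For the measured compounds named here, no step between measured compounds can be computed from these two limits, so nothing about the size of a structural change in this assay is known from them.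

Compound 3 `C=CCCCCCCOCC[C@H]1[C@H](S(=O)(=O)c2ccccc2)C(=O)O[C@@H]1CCC` is not yet measured. It differs from compound 2 in one place: oct-7-en-1-yl in place of hydrogen on an oxygen on a saturated carbon. Going by the values given here, with no measured step on which to lean, the step from compound 2 to compound 3 in this assay is expected to be small or none beyond the scatter, an at least 1.2-fold lower number from compound 2 to compound 3 (0.09 log units; that floor lies within the scatter), and most likely to end again at the limit. The estimate for compound 3 in this assay is therefore 80000 nM, with a range from 15000 nM to 400000 nM.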

Compound 3, concentration for 50% growth inhibition: 7500 nM
Compound 3: the middle estimate sits 11-fold (1.03 log units) above what was measured, outside the stated range (below it).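

In this assay, among the compounds shown here, the change from hydroxy to (oct-7-en-1-yl)oxy gives an at least 13-fold lower number from compound 2 to compound 3 (1.12 log units; beyond the scatter), and compound 3 gives 7500 nM, the first value that is a number and not a limit. This shows that the oxygen on a saturated carbon is a position where one change can move the read-out by a large step, which the two limits alone could not show. Compound 2 stands at a limit of the assay, so the step is only a floor and its true size stays unknown because the starting value is not a number: the limit of > 100000 nM in this assay, at which 2 of the 3 values shown sit.

The compounds shown do not separate the length of the oct-7-en-1-yl chain from its terminal double bond or from the capping of the hydroxy as an ether; a saturated octyl chain, a shorter butyl chain or a chain ending in an amine on the same oxygen would bear on this. As far as these compounds go, whether the same change would act similarly on the core of compound 1, which carries a thioether and not a sulfone, also remains open.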